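This account rests on a few compounds, and the source may have more. Where it says the series, first, only, none or still open, it means among the compounds named here.

Compound 2 `C=CC1=C(C(=O)Nc2ccccc2)C(c2ccc(F)cc2)OC1` is tested in a functional assay on HeLa cells (Homo sapiens) for cytotoxicity, read by MTT assay, with a stated time of 24 h (a higher number here means a weaker inhibitor, a lower number a stronger inhibitor), where compound 2 gives > 100000 nM, a limit of the assay. Compound 1 `C=CC1=C(C(=O)Nc2ccccc2)C(c2ccc(Cl)c(Cl)c2)OC1` differs from it by 3,4-dichlorophenyl in place of 4-fluorophenyl on a saturated ring carbon; in this assay compound 1 gives > 100000 nM, again a limit. The step that the two limits leave unreadable from compound 2 to compound 1 therefore cannot be read, because of the limit of > 100000 nM in this assay, at which 3 of the 3 values shown sit. The core of compound 3 `C=CC1=C(C(=O)NCc2ccccc2)C(c2ccc(F)cc2)OC1` differs from that of compound 2 by benzyl in place of phenyl on an amide-type nitrogen; in this assay compound 3 gives > 100000 nM, also a limit, so the step that the two limits leave unreadable from compound 2 to compound 3 is unreadable as well. Compound 4 `C=CC1=C(C(=O)NCc2ccccc2)C(c2ccc(Cl)c(Cl)c2)OC1` has not been measured. It differs from compound 3 by 3,4-dichlorophenyl in place of 4-fluorophenyl on a saturated ring carbon, the same kind of change as from compound 2 to compound 1, though here the place is described as next to the ring atom that bears a large group rather than a group of 9 heavy atoms. Because the earlier step that the two limits leave unreadable from compound 2 to compound 1 gave no readable size, the expected step of a number no higher from compound 3 to compound 4 (the limit leaves the size open) rests only on the shared limit. Compound 4 is thus expected to give about 100000 nM, estimated to lie between 30000 nM and 300000 nM.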

Compound 4, half-maximal inhibitory concentration: > 100000 nM
Compound 4 was reported as a limit; the forecaster's own chance of this, stated with the estimate: 80%; the middle value lies on the limit itself.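

Compound 4 also sits at a limit of the assay, so neither its step from compound 3 nor its step from compound 1 can be read: the limit of > 100000 nM in this assay, at which 4 of the 4 values shown sit.

The compounds shown leave open whether any change to the shared core would give a readable value in this assay.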